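A Longer Chain on a Long-Lasting Compound

A few compounds are considered here, and "the series" means these few. Any claim that something is new, unique, unknown or untested is made for them only; others in the source may bear on it.

In an ADME assay on liver for metabolic stability, with Liver microsome (Homo sapiens) as the target, read by HPLC, using microsomes (a higher number here means that the compound lasts longer, a lower number that the compound disappears faster), compound 1 `COCCOc1cc2ncnc(-n3nc(-c4ccccn4)nc3N)c2cc1OCCOC` gives 1.6 h. Compound 2 `COCCOc1cc2c(-n3nc(-c4ccccn4)nc3N)ncnc2cc1OC` gives > 4 h, which is a limit of the assay and not a number. Compound 3 `COc1cc2ncnc(-n3nc(-c4ccccn4)nc3N)c2cc1OCCCNC(=O)OC(C)C` differs from compound 2 by ((isopropoxycarbonyl)amino)methyl in place of methoxy on a saturated chain carbon, two bonds along the chain from an oxygen on an aromatic ring, so 2-methoxyethoxy becomes 3-((isopropoxycarbonyl)amino)propoxy. For the measured compounds named here, the one measured step, an at least 2.5-fold higher number from compound 1 to compound 2 (0.39 log units; beyond the scatter), came with hydrogen in place of methoxymethyl. It shortened a different chain, so it is only a rough guide. Lengthening this chain is therefore expected to give an at least 2.0-fold lower number from compound 2 to compound 3 (0.30 log units; that floor lies within the scatter), a move towards faster disappearance. The estimate for compound 3 is 2 h, expected to fall between 0.8 h and 4.5 h.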

Compound 3, half-life: 1.1 h
Compound 3: middle estimate off by 1.8-fold (0.26 log units), on the high side; the measured number falls inside the stated range.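

Replacing 2-methoxyethoxy with 3-((isopropoxycarbonyl)amino)propoxy gives, in this assay, an at least 3.6-fold lower number from compound 2 to compound 3 (0.56 log units; beyond the scatter). The earlier step concerned a different chain, so this shows that the group at this position also affects how long the compound lasts. The value of compound 2 is a limit and not a number, so the size of this step is only a floor: the limit of > 4 h in this assay, at which 1 of the 3 values shown sits.

Chain length and end group changed together here, and the compounds shown do not separate them. A plain propoxy chain or an amine at the end of the chain would address that question.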